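Cyano for Hydrogen on the Benzyl Ring: Cytotoxicity Outlook

The source may hold more compounds than are shown below. What is called first, only, known or untested is meant among the compounds shown, and "the series" means these compounds.

Measured compounds:
compound 1 `O=C1N(Cc2ccccc2Br)c2cccn2S(=O)(=O)N1Cc1cccc(F)c1` — > 269000 nM
compound 2 `O=C1N(Cc2ccccc2)c2cccn2S(=O)(=O)N1Cc1cccc(F)c1` — > 288000 nM

Of the compounds shown here, two have been measured in an ADME assay on MT4 cells (Homo sapiens) for cytotoxicity, read by MTT assay, with a stated time of 5 days; on this read-out lower numbers stand for higher toxicity in this test and higher numbers for lower toxicity in this test. Compound 1 `O=C1N(Cc2ccccc2Br)c2cccn2S(=O)(=O)N1Cc1cccc(F)c1` carries a bromo group on its benzyl ring; in this assay compound 1 gives > 269000 nM, which is a limit of the assay and not a number. Compound 2 `O=C1N(Cc2ccccc2)c2cccn2S(=O)(=O)N1Cc1cccc(F)c1` carries hydrogen in its place. In this assay compound 2 gives > 288000 nM, again a limit of the assay only. The step that the two limits leave unreadable from compound 1 to compound 2 therefore cannot be read, as both the limit of > 269000 nM in this assay, at which 1 of the 2 values shown sits, and the limit of > 288000 nM in this assay, at which 1 of the 2 values shown sits, show. Compound 2 thus stands at a limit of the assay rather than at a number.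

Compound 3 `N#Cc1ccccc1CN1C(=O)N(Cc2cccc(F)c2)S(=O)(=O)n2cccc21` differs from compound 2 in one place: cyano in place of hydrogen on an aromatic carbon. Within the data shown here, no measured step involves a cyano group, and the only step available, a step that the two limits leave unreadable from compound 1 to compound 2, is itself unreadable. No change beyond the scatter is therefore expected in this assay, and compound 3 is expected to remain at a limit. The step that the limit leaves unreadable from compound 2 to compound 3 is estimated as essentially flat. Compound 3 is estimated at 300000 nM, between 150000 nM and 1000000 nM.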

Compound 3, half-maximal cytotoxic concentration: > 305000 nM
Compound 3 ended at the assay's limit; the forecaster's own chance of this, stated with the estimate: 85%; middle value at least 1.0-fold (0.00 log units) away from the limit.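

In this assay compound 3 gives > 305000 nM, which is a limit of the assay and not a number. Among these compounds, with compound 1 and compound 2 also at limits, no step linking compound 3 to either can be read. The compounds shown leave open whether bromo, cyano or hydrogen on the benzyl ring changes cytotoxicity at all.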